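The source may hold more compounds than are shown below. What is called first, only, known or untested is meant among the compounds shown, and "the series" means these compounds.

Of the compounds shown here, two have so far been measured in a functional assay on SK-BR-3 cells (Homo sapiens) for cytotoxicity, read by resazurin assay, with a stated time of 72 h; on this read-out lower numbers stand for stronger inhibition and higher numbers for weaker inhibition. Compound 1, with the structure `S=C(NCc1cccnc1)SCCc1nnn[nH]1`, gives only the limit > 100000 nM in this assay, so no number is known for it. The value of compound 1 is the limit of > 100000 nM in this assay, at which 1 of the 2 values shown sits. Among the measured compounds shown here, compound 2, with the structure `Fc1ccccc1-c1nnc(CCSC(=S)NCc2cccnc2)o1`, gives 4690 nM in this assay, and it is the only compound of the two for which a number rather than a limit has been found. Compound 3, with the structure `S=C(NCc1cccnc1)SCCc1nnc(-c2cc[nH]c2)o1`, has not yet been measured in this assay. It differs from compound 2 in one place: 1H-pyrrol-3-yl in place of 2-fluorophenyl on an aromatic carbon. For the measured compounds named here, no pair of measured compounds differs in a single place, so no measured step shows how a change of this kind acts here, and the expectation for compound 3 rests on compound 2 alone. The step of a 2.6-fold higher number from compound 2 to compound 3 (0.41 log units; beyond the scatter) is the expected change, a modest loss of potency that may fall within the usual scatter or a little beyond it. Compound 3 is therefore expected to give about 12000 nM in this assay, with a likely range from 3000 nM to 50000 nM.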

Compound 3, half-maximal inhibitory concentration: 820 nM
Beside the measured number, compound 3's estimate is 15-fold (1.17 log units) above it; measured number outside the range, below it.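

Among the compounds shown here, at this position, on an aromatic carbon of the five-membered aromatic ring with 2 nitrogen and 1 oxygen, the swap of 2-fluorophenyl for 1H-pyrrol-3-yl gives a 5.7-fold lower number from compound 2 to compound 3 (0.76 log units; beyond the scatter) in this assay and thus the only measured change at this place. It shows that the 2-fluorophenyl group is not required for the activity of compound 2, since a smaller five-membered aromatic ring with 1 hetero atom and 1 hydrogen-bond donor does better there. The information on hand gives no measured reason why this swap lowers the number.

This single step changes several things at once, namely the fluorine, the ring size, and the ring nitrogen with its hydrogen, so it cannot say which of them matters. Plain phenyl and furan-3-yl at the same place would help separate these features, while an amine or a carboxylic acid on the ring would show how far this position accepts further change.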